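The compounds below may be only part of what the source reports. "The series", "measured", "known", "first", "only" and "open" are said of these compounds alone.

In an ADME assay on THP-1 cells (Homo sapiens) for cytotoxicity (on this read-out lower numbers stand for stronger inhibition and higher numbers for weaker inhibition), compound 1 `COc1ccccc1-c1nnc(-c2ccc(C(=O)N/N=C/c3ccc(O)c(O)c3)cc2)o1` gives 100000 nM, and compound 2 `COc1ccccc1-c1nnc(-c2ccc(C(=O)N/N=C/c3cccnc3)cc2)o1` gives 167000 nM. Within the data shown here, compound 2 therefore has the higher of the two numbers so far, with compound 1 as its only neighbour; the step of a 1.7-fold higher number from compound 1 to compound 2 (0.22 log units; within the scatter) lies within the scatter, so the two compounds cannot be placed in any order on this assay.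

Compound 3 `COc1ccccc1-c1nnc(-c2ccc(C(=O)N/N=C/c3ccc(O)cc3)cc2)o1` has not yet been measured. Relative to compound 2 its change is 4-hydroxyphenyl in place of pyridin-3-yl on a carbon with a double bond to nitrogen. Among the measured compounds shown here, only one measured step bears on this change: the one from compound 1 to compound 2, which exchanged 3,4-dihydroxyphenyl for pyridin-3-yl on the carbon double-bonded to nitrogen and produced no movement beyond the scatter. Compound 3 places a 4-hydroxyphenyl group at the same position, so the available evidence points to a step in this assay that again falls within the scatter, with no clear direction. Compound 3 is accordingly expected to show a 1.4-fold lower number from compound 2 to compound 3 (0.14 log units; within the scatter). The estimate for compound 3 in this assay is 120000 nM, with a range from 55000 nM to 260000 nM.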

Compound 3, half-maximal inhibitory concentration: 261000 nM
Beside the measured number, compound 3's estimate is 2.2-fold (0.34 log units) below it; measured number above the stated range.
By their numbers in this assay, from the lowest: compounds 1, 2 and 3 (each within the scatter of the next, the first and the last beyond it).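

In this assay, among these compounds, replacing 3,4-dihydroxyphenyl with 4-hydroxyphenyl, which puts hydrogen in place of hydroxy on an aromatic carbon, gives a 2.6-fold higher number from compound 1 to compound 3 (0.42 log units; beyond the scatter) and is the first modest step at this position to pass beyond the scatter. Replacing pyridin-3-yl with 4-hydroxyphenyl gives a 1.6-fold higher number from compound 2 to compound 3 (0.19 log units; within the scatter) and so does not separate these two groups, even though the entering ring is of carbon only and carries a hydrogen-bond donor that pyridin-3-yl lacks. Nothing available explains either step.

The compounds shown leave open whether the separation of compound 1 and compound 3 reflects the loss of that one hydroxy alone or would hold for other groups on this carbon with a double bond to nitrogen. They also leave open how the number would respond to a plain phenyl ring, or to a phenyl ring carrying an amine, a carboxylic acid or a methoxy group, in place of the hydroxylated rings and pyridin-3-yl.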